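The compounds below may be only part of what the source reports. "The series", "measured", "known", "first", "only" and "open" are said of these compounds alone.

Measured compounds:
- compound 1, `CCCc1nc(-c2ccccc2)c(CNCCCN2CCN(c3cccc(C)c3C)CC2)o1`: 1780 nM
- compound 2, `CCCc1nc(-c2ccccc2)c(CNCCCN2CCN(c3ccc(F)cc3)CC2)o1`: 3210 nM
- compound 3, `CCCc1nc(-c2ccccc2)c(CNCCCN2CCN(c3ccccc3Cl)CC2)o1`: 2800 nM

All three share one core and differ only in the aryl group on the ring amine nitrogen. In an assay on HEK293 cells for inhibition of Voltage-dependent T-type calcium channel subunit alpha-1G (Homo sapiens), read by patch clamp (a lower number here means a stronger inhibitor, a higher number a weaker inhibitor), compound 3 gives 2800 nM, the second highest of the three numbers. Its closest neighbour is compound 2, a 1.1-fold lower number from compound 2 to compound 3 (0.06 log units; within the scatter), and the widest gap is to compound 1, a 1.6-fold higher number from compound 1 to compound 3 (0.20 log units; within the scatter); both gaps are within the scatter, so the three aryl groups cannot be told apart on these numbers.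

Compound 4, `CCCc1nc(-c2ccccc2)c(CNCCCN2CCN(c3ccccc3C)CC2)o1`, has not been measured yet. Relative to compound 3 the change is methyl in place of chloro on an aromatic carbon.

For the measured compounds named here, the steps that bear on this are the ones already seen: a 1.8-fold higher number from compound 1 to compound 2 (0.26 log units; within the scatter) and a 1.6-fold higher number from compound 1 to compound 3 (0.20 log units; within the scatter), each within the scatter, so swapping one small aryl substituent for another has so far made no difference that can be trusted. Compound 1 already carries a methyl at this position and sits at 1780 nM, in the same band. The expectation for compound 4 in this assay is therefore no step beyond the scatter: a 1.2-fold lower number from compound 3 to compound 4 (0.07 log units; within the scatter). Compound 4 is estimated at 2400 nM, with a range from 1100 nM to 5500 nM.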

Compound 4, half-maximal inhibitory concentration: 8750 nM
Compound 4: the middle estimate sits 3.6-fold (0.56 log units) below what was measured; the whole stated range lies below it.
By their numbers in this assay, from the lowest: compounds 1, 3 and 2 (each within the scatter of the next); then compound 4.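

In this assay, for the compounds shown here, this position is not as forgiving as the earlier compounds suggested: methyl in place of chloro, on an aromatic carbon ortho to a large group, gives a 3.1-fold higher number from compound 3 to compound 4 (0.49 log units; beyond the scatter), the kind of step none of the earlier aryl swaps produced, even though one heavy atom simply replaces another and neither group has a hydrogen-bond donor, acceptor or net charge. The methyl also does not act the same way in every setting, since hydrogen in place of the second methyl of the 2,3-dimethylphenyl group gives a 4.9-fold higher number from compound 1 to compound 4 (0.69 log units; beyond the scatter), so the 2-methylphenyl group falls short of a group that carries one more methyl, and a 2.7-fold higher number from compound 2 to compound 4 (0.44 log units; beyond the scatter) shows that it falls short of the 4-fluorophenyl group too. Compound 4 is therefore the weakest inhibitor of the four, and a change of a single atom on this aryl ring can separate compounds that otherwise share everything.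

Nothing shown here gives a reason for this gap. On these data alone, it also remains open how a methoxy or a trifluoromethyl group in the same place, or a phenyl ring with no substituent at all, would compare with the chloro and methyl groups.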